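The source may report more compounds than this note shows. Statements on the series, on what has been measured and on what is new or still open speak of the compounds shown alone.

Measured so far:
Compound 1, `COc1ccc(-c2cs/c(=N/NC(=O)CSc3nnnn3-c3ccccc3)n2-c2ccccc2)cc1`: in an ADME assay on NIH3T3 cells (Mus musculus) for cytotoxicity, read by MTT assay, with a stated time of 24 h (on this read-out lower numbers stand for stronger inhibition and higher numbers for weaker inhibition), compound 1 gives 11.7 ug/mL.
Compound 2, `Cc1ccc(-c2cs/c(=N/NC(=O)CSc3nnnn3-c3ccccc3)n2-c2ccccc2)cc1`: in this assay compound 2 is reported only as a limit of the assay, > 500 ug/mL.
Compound 3, `Cc1ccc(-c2cs/c(=N/NC(=O)CSc3ncccn3)n2-c2ccccc2)cc1`: in this assay compound 3 is likewise reported only as a limit, > 500 ug/mL.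

Only compound 1 has a measured number. Compound 2 becomes compound 1 by a single change, (methoxy in place of methyl on an aromatic carbon), and this change made the step of an at least 42-fold lower number from compound 2 to compound 1 (1.63 log units; beyond the scatter). Compound 2 becomes compound 3 by a different change, (pyrimidin-2-yl in place of 1-phenyl-1H-tetrazol-5-yl on a sulfur); the step that the two limits leave unreadable from compound 2 to compound 3 cannot be sized because of the limit of > 500 ug/mL in this assay, at which 2 of the 3 values shown sit.

Compound 4, `COc1ccc(-c2cs/c(=N/NC(=O)CSc3ncccn3)n2-c2ccccc2)cc1`, has not yet been measured. It differs from compound 3 by methoxy in place of methyl on an aromatic carbon, which is the same change that separates compound 2 from compound 1, with the place described in the same words in both cases. The cores of compound 3 and compound 4 differ from those of compound 2 and compound 1 as described by pyrimidin-2-yl in place of 1-phenyl-1H-tetrazol-5-yl on a sulfur.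

Compound 4 is expected to show the step of an at least 8.3-fold lower number from compound 3 to compound 4 (0.92 log units; beyond the scatter). That expectation rests on compound 1, whose step an at least 42-fold lower number from compound 2 to compound 1 (1.63 log units; beyond the scatter) followed the same change, tempered by the fact that the cores differ and that compound 3 starts from a limit. For compound 4 the estimated value in this assay is 60 ug/mL, expected to fall between 10 ug/mL and 500 ug/mL.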

Compound 4, half-maximal inhibitory concentration: 450 ug/mL
The estimate for compound 4 lay 7.5-fold (0.88 log units) below the measured number; low and high end bracket the measured number.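

In this assay, the change from 4-methylphenyl to 4-methoxyphenyl can be set side by side on the two cores: the same change on two cores in this assay, an at least 42-fold lower number (1.63 log units; beyond the scatter) from compound 2 to compound 1 and an at least 1.1-fold lower number (0.04 log units; that floor lies within the scatter) from compound 3 to compound 4; the limit leaves it open whether they differ

On the core carrying pyrimidin-2-yl, the step is an at least 1.1-fold lower number from compound 3 to compound 4 (0.04 log units; that floor lies within the scatter), so the large drop seen on the other core is not shown to carry over, but it is not shown to fail either, since compound 2 and compound 3 are each reported only as a limit, not as a number: the limit of > 500 ug/mL in this assay, at which 2 of the 4 values shown sit.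

The firm result is the comparison with methoxy present on both compounds, where pyrimidin-2-yl in place of 1-phenyl-1H-tetrazol-5-yl on the sulfur gives a 38-fold higher number from compound 1 to compound 4 (1.59 log units; beyond the scatter), so the group on the sulfur clearly changes the read-out when methoxy is held fixed.

The compounds shown leave open how the methoxy step would read on a core whose methyl partner gives a real number rather than a limit, and so how far the two steps truly differ. They also leave open what other groups would do, such as a chlorine or a hydroxyl in place of methoxy, or a simple phenyl or a chain ending in an amine on the sulfur.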